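A few compounds are considered here, and "the series" means these few. Any claim that something is new, unique, unknown or untested is made for them only; others in the source may bear on it.

Measured in an ADME assay on HEK293 cells (Homo sapiens) for cytotoxicity, read by resazurin assay, with a stated time of 48 h; on this read-out higher numbers stand for lower toxicity in this test and lower numbers for higher toxicity in this test:
- compound 1 `CS(=O)(=O)Nc1ccc(-c2nc3ccccc3o2)cc1`: > 100000 nM, a limit of the assay
- compound 2 `O=S(=O)(Nc1ccc2oc(-c3ccccc3)nc2c1)c1cccc(Cl)c1`: 70000 nM
- compound 3 `O=S(=O)(Nc1ccc2oc(-c3ccccc3)nc2c1)c1ccc(O)cc1`: > 100000 nM, a limit of the assay

Compound 1 has no exact number in this assay, only its limit of > 100000 nM. Compound 4 `CCc1ccc(S(=O)(=O)Nc2ccc(-c3nc4ccccc4o3)cc2)cc1` departs from it at one place: 4-ethylphenyl in place of methyl on a sulfonyl sulfur.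

For the measured compounds named here, no measured step makes this exchange directly. Compound 2 and compound 3 carry aromatic rings on the sulfonyl sulfur, but they also differ from compound 1 elsewhere. Going by the values given here, the one measured step between such groups is an at least 1.4-fold higher number from compound 2 to compound 3 (0.15 log units; that floor lies within the scatter), so it offers no sign that the choice of ring matters much here. The evidence is also thin at the top of the range, with the limit of > 100000 nM in this assay, at which 2 of the 3 values shown sit. Among the compounds with values here, compound 2 gives the only exact number, 70000 nM, and it is the closest guide to how a compound with a ring at this place may read.

A modest move towards a lower number is therefore expected, though it may not clear the scatter, and compound 4 could also end up at the limit. The expected step is an at least 1.4-fold lower number from compound 1 to compound 4 (0.15 log units; that floor lies within the scatter). For compound 4 the estimated value is 70000 nM, with an expected range of 30000 nM to 100000 nM.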

Compound 4, half-maximal cytotoxic concentration: 82000 nM
Compound 4: middle estimate off by 1.2-fold (0.07 log units), on the low side; the measured number falls inside the stated range.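

In this assay, the exchange of methyl for 4-ethylphenyl on a sulfonyl sulfur can now be read directly on the core of compound 1, and it gives an at least 1.2-fold lower number from compound 1 to compound 4 (0.08 log units; that floor lies within the scatter). For the compounds shown here, the earlier compounds offered rings at this place only on a different arrangement of the core, so this is the first sign that, on this core, a group of this size with a six-membered aromatic ring still leaves an exact number high in the range, with no step beyond the scatter. The true size of the step remains unknown, because the reading for compound 1 is only a limit of the assay: the limit of > 100000 nM in this assay, at which 2 of the 4 values shown sit.

The compounds shown leave open whether the ethyl group contributes anything to the reading of compound 4, or whether a plain phenyl ring on the sulfonyl sulfur would read the same on this core. They also leave open how an amine, a carboxylic acid or a longer alkyl chain at this place would read in this assay, and whether any such group would give a step that clears the scatter.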